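This account rests on a few compounds, and the source may have more. Where it says the series, first, only, none or still open, it means among the compounds named here.

Measured so far:
compound 1 `Cc1cc2[nH]nc(N)c2c(=O)[nH]1` with 8%
compound 2 `COc1cccc(-c2cc3[nH]nc(N)c3c(=O)[nH]2)c1` with 10%
compound 3 `Cc1cc2c(c(N)nn2C)c(=O)[nH]1` with 5%

All three were tested in an assay on isolated protein for inhibition of MAP kinase-activated protein kinase 5 (Homo sapiens), read by mobility shift assay, tested at 30 uM; a higher number here means more inhibition at the concentration tested (going by the name of the read-out), a lower number less inhibition. Compound 3 gives the lowest of the three numbers, but its gap to compound 1 and to compound 2 is within the scatter, so the three compounds cannot be told apart on these data. Among the compounds with values here, the one measured step is a number 3 percentage points lower from compound 1 to compound 3 (within the scatter), which concerns a methyl on an aromatic nitrogen and says nothing about the aromatic carbon that changes next.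

Compound 4 `Cn1nc(N)c2c(=O)[nH]c(-c3ccccn3)cc21` differs from compound 3 as follows: pyridin-2-yl in place of methyl on an aromatic carbon. Within the data shown here, no measured step covers this exchange. Compound 1 carries a methyl on that carbon and compound 2 a larger aromatic group there, and their values in this assay are close to each other, which hints that the group on this carbon has made little difference so far. A step in this assay is therefore expected to stay within the scatter, as a number 3 percentage points higher from compound 3 to compound 4 (within the scatter). Compound 4 is estimated at 8%, between 0% and 25%.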

Compound 4, a percentage reported as inhibition, at one concentration (the size of the read-out at that concentration, not a potency): 9%
For compound 4 the middle estimate is 1 percentage points below the measured one, and the stated range covers the measured number.
By their numbers in this assay, from the lowest: compounds 3, 1, 4 and 2 (each within the scatter of the next).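

Putting pyridin-2-yl in place of methyl on this aromatic carbon, while the methyl on the aromatic nitrogen stays, gives a number 4 percentage points higher from compound 3 to compound 4 (within the scatter) in this assay. Within the data shown here, this is the first measured exchange at this carbon that changes nothing else, and it shows that six heavy atoms with a six-membered aromatic ring can replace the single carbon of methyl without a difference that can be told from the scatter. Nothing measured here offers an explanation for this result.

Among these compounds, with every step so far within the scatter, it remains open whether any group on this carbon can shift the inhibition in this test at all. An amine, a carboxylic acid or a longer alkyl chain on this carbon would probe that question with groups quite unlike the methyl and pyridin-2-yl seen in this pair.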